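Replacing 3-cyanophenyl with 2,5-dichlorophenyl on the shared core

The source may report more compounds than this note shows. Statements on the series, on what has been measured and on what is new or still open speak of the compounds shown alone.

Compound 1 `COc1cccc(C(=O)NCCNC(=O)[C@H](CC(=O)NC(C)(C)C)NS(=O)(=O)c2ccc(C)cc2)c1`: > 11000 nM (a limit)
Compound 2 `Cc1ccc(S(=O)(=O)N[C@@H](CC(=O)NC(C)(C)C)C(=O)NCCNC(=O)c2cccc(C#N)c2)cc1`: > 11000 nM (a limit)

In an ADME assay on HepG2 cells (Homo sapiens) for cytotoxicity (a lower number here means that less compound is needed, a higher number that more compound is needed for the effect), compound 2 gives > 11000 nM, which is a limit and not a number. The picture so far is short: the limit of > 11000 nM in this assay, at which 2 of the 2 values shown sit. Compound 3 `Cc1ccc(S(=O)(=O)N[C@@H](CC(=O)NC(C)(C)C)C(=O)NCCNC(=O)c2cc(Cl)ccc2Cl)cc1` keeps the shared core of compound 2 and changes one group, with 2,5-dichlorophenyl in place of 3-cyanophenyl on a carbonyl carbon. Going by the values given here, only one measured step bears on this change, and it concerns a different swap, cyano in place of methoxy on an aromatic carbon. That step is a step that the two limits leave unreadable from compound 1 to compound 2, so it offers no size to carry over. No shift beyond the scatter is therefore expected in this assay, and no direction can be argued. The expected change is a step that the limit leaves unreadable from compound 2 to compound 3. For compound 3 the estimated value is 15000 nM, with an expected range of 7000 nM to 30000 nM.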

Compound 3, half-maximal effective concentration: > 11000 nM
Compound 3: only a limit was reported; the forecaster's own chance of this, stated with the estimate: 75%; the middle value is on the limit's open side.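

In this assay compound 3 is reported only as a limit, as are compound 1 and compound 2, so neither step leading to compound 3 can be read. The compounds shown leave open how much of any of them is needed for the effect, and whether changing the aryl group on this carbonyl carbon shifts that amount at all.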